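Swapping a Methylphenyl for a Dichlorophenyl

The compounds below may be only part of what the source reports. "The series", "measured", "known", "first", "only" and "open" are said of these compounds alone.

Of the compounds shown here, three sharing one core have been tested in a functional assay on Bel-7402 cells (Homo sapiens) for cytotoxicity, read by MTT assay; on this read-out higher numbers stand for weaker inhibition and lower numbers for stronger inhibition. Compound 1 `COc1cc(/C=C/C(=O)c2sc(Nc3ccccc3C)nc2C)cc(OC)c1OC` gives 10300 nM in this assay. Compound 2 `COc1cc(/C=C/C(=O)c2sc(Nc3ccc(C)cc3)nc2C)cc(OC)c1OC` reaches only a limit of the assay, > 25000 nM, and no actual number is known for it. Compound 3 `Cc1cccc(Nc2nc(C)c(C(=O)/C=C/c3ccccc3Cl)s2)c1` likewise sits at a limit, > 25000 nM. Among the compounds with values here, the single step between compounds that differ in one place is an at least 2.4-fold higher number from compound 1 to compound 2 (0.38 log units; beyond the scatter), a weakening that ends at the limit of > 25000 nM in this assay, at which 2 of the 3 values shown sit. Compound 4 `COc1cc(/C=C/C(=O)c2sc(Nc3ccc(Cl)c(Cl)c3)nc2C)cc(OC)c1OC` has not been measured yet; it differs from compound 2 by 3,4-dichlorophenyl in place of 4-methylphenyl on a nitrogen on an aromatic ring. Within the data shown here, no measured pair replaces a 4-methylphenyl with a 3,4-dichlorophenyl, and the only anchor is that compound 2 itself stands at the assay limit. The step from compound 2 to compound 4 is expected to be an at least 1.2-fold lower number from compound 2 to compound 4 (0.09 log units; that floor lies within the scatter), with no firm direction. Compound 4 is expected to give about 20000 nM, within a range from 6000 nM to 60000 nM, and it may well land at the limit once more.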

Compound 4, half-maximal inhibitory concentration: > 25000 nM
Compound 4 was reported as a limit; the forecaster's own chance of this, stated with the estimate: 55%; middle value at least 1.2-fold (0.09 log units) from the limit.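

Putting a 3,4-dichlorophenyl in place of the 4-methylphenyl on the nitrogen brings back no readable number in this assay: compound 4 gives > 25000 nM, which is a limit of the assay and not a number. Compound 2 is also a limit, so the step between these two compounds cannot be read, but a second comparison can: an at least 2.4-fold higher number from compound 1 to compound 4 (0.38 log units; beyond the scatter). Both the 4-methylphenyl and the 3,4-dichlorophenyl therefore fall short of the 2-methylphenyl of compound 1, and the series now crowds against a single ceiling: the limit of > 25000 nM in this assay, at which 3 of the 4 values shown sit.

As far as these compounds go, how far compound 2 and compound 4 lie past that limit stays unknown. Also open, from the compounds shown here alone, is whether a phenyl carrying an amine or a carboxylic acid at this place would give a lower number than compound 1.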